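The compounds below may be only part of what the source reports. "The series", "measured", "known", "first", "only" and "open" are said of these compounds alone.

In an ADME assay on microsomes from liver (Homo sapiens) for metabolic stability, with a stated time of 10 min (a higher number here means that more of the compound is left, a lower number that less of the compound is left), compound 2 (`O=C(O)C12CCC(C(=O)N3CC[C@](c4ccc(C(F)(C(F)(F)F)C(F)(F)F)cc4)(S(=O)(=O)c4ccc(F)cc4)C3)(CC1)OC2`) gives 90%, within the scatter of compound 1 (`C[C@]1(C(=O)N2CC[C@](c3ccc(C(F)(C(F)(F)F)C(F)(F)F)cc3)(S(=O)(=O)c3ccc(F)cc3)C2)CC[C@@H](C(=O)O)CC1`) at 85%. For the measured compounds named here, compound 3 (`O=C(C1CCS(=O)(=O)C1)N1CC[C@](c2ccc(C(F)(C(F)(F)F)C(F)(F)F)cc2)(S(=O)(=O)c2ccc(F)cc2)C1`) gives 100%; 100% (2 entries), but no single-place step links it to compound 4. Compound 4 (`CCC1(C(=O)N2CC[C@](c3ccc(C(F)(C(F)(F)F)C(F)(F)F)cc3)(S(=O)(=O)c3ccc(F)cc3)C2)CCS(=O)(=O)CC1`) differs from compound 2 by a group of 10 heavy atoms (7 carbon, 2 oxygen, 1 sulfur; one six-membered non-aromatic ring with 1 hetero atom) in place of a group of 11 heavy atoms (8 carbon, 3 oxygen; one six-membered non-aromatic ring of carbon only, one six-membered non-aromatic ring with 1 hetero atom), on a carbonyl carbon. The entering 4-ethyl-1,1-dioxothian-4-yl has 0 hydrogen-bond donors, the leaving group 1. Going by the values given here, the one measured step that bears on this change, a number 5 percentage points higher from compound 1 to compound 2 (within the scatter), also alters the group on a carbonyl carbon and remains small. No step beyond the scatter is therefore expected in this assay, and the estimated step is a number 2 percentage points higher from compound 2 to compound 4 (within the scatter). For compound 4 the estimate is 92%, with an expected range from 80% to 100%.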

Compound 4, percent of the compound remaining: 3%
Compound 4: middle estimate off by 89 percentage points, on the high side, outside the stated range (below it).
By their numbers in this assay, from the lowest: compound 4; then compounds 1 and 2 (each within the scatter of the next).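

In this assay, the group on the carbonyl carbon can matter greatly: 4-ethyl-1,1-dioxothian-4-yl gives a number 87 percentage points lower from compound 2 to compound 4 (beyond the scatter) and a number 82 percentage points lower from compound 1 to compound 4 (beyond the scatter), whereas the earlier exchange at this place gave only a number 5 percentage points higher from compound 1 to compound 2 (within the scatter). The entering group has 0 hydrogen-bond donors and the group leaving compound 2 has 1, but this change comes together with a change of ring. Nothing available explains the drop.

Whether the ethyl chain, the ring or the missing carboxylic acid accounts for it stays open. A methyl in place of the ethyl, or a carboxylic acid on the same ring, would help separate these.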